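Chloro-bearing core: a thiophenylmethyl amide in place of pyridyl

This account rests on a few compounds, and the source may have more. Where it says the series, first, only, none or still open, it means among the compounds named here.

Compound 2 `O=C(Cn1c(=O)oc2cc(Cl)ccc21)Nc1ccccn1` holds the higher of the two numbers in an ADME assay on RAW264.7 cells (Mus musculus) for cytotoxicity, read by MTT assay, with a stated time of 72 h, tested at 50 uM (a lower number here means a weaker effect, a higher number a stronger effect of the compound at the concentration tested), where compound 2 gives 33%. Its nearest neighbour, compound 1 `O=C(Cn1c(=O)oc2ccccc21)NCc1cccs1`, gives 23.4% in this assay, a gap that lies within the scatter. Compound 3 `O=C(Cn1c(=O)oc2cc(Cl)ccc21)NCc1cccs1` differs from compound 2 by (thiophen-2-yl)methyl in place of pyridin-2-yl on an amide-type nitrogen. Among the measured compounds shown here, no step between measured compounds is available for this change, so the expected step is a number 5 percentage points lower from compound 2 to compound 3 (within the scatter), none beyond the scatter in either direction. Compound 3 is therefore expected to give 28%, with a range from 12% to 45%.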

Compound 3, a percentage reported as inhibition, at one concentration (the size of the read-out at that concentration, not a potency): 20.3%
Beside the measured number, compound 3's estimate is 7.7 percentage points above it; low and high end bracket the measured number.
By their numbers in this assay, from the lowest: compounds 3, 1 and 2 (each within the scatter of the next, the first and the last beyond it).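

In this assay, among the compounds shown here, (thiophen-2-yl)methyl in place of pyridin-2-yl on the amide-type nitrogen gives a number 12.7 percentage points lower from compound 2 to compound 3 (beyond the scatter), the first single change here that goes beyond the scatter. Chloro in place of hydrogen on an aromatic carbon, with the (thiophen-2-yl)methyl amide kept, gives only a number 3.1 percentage points lower from compound 1 to compound 3 (within the scatter). No measurement shown here explains the larger step.

This change swaps the ring and adds a carbon link together, so the compounds shown cannot say which of the two carries the step; a (pyridin-2-yl)methyl group on the same nitrogen would separate them. On these data alone, whether chloro has as little effect alongside pyridin-2-yl also remains open.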